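This account rests on a few compounds, and the source may have more. Where it says the series, first, only, none or still open, it means among the compounds named here.

Values in an ADME assay on WI-38 cells (Homo sapiens) for cytotoxicity, read by MTT assay, with a stated time of 72 h; a lower number here means a stronger inhibitor, a higher number a weaker inhibitor:

Compound 1 `CCNC(=O)CCc1cccc2c1B(O)OC2` gives > 100000 nM (a limit).
Compound 2 `CC(C)(C)NC(=O)CCc1cccc2c1B(O)OC2` gives > 100000 nM (a limit).
Compound 3 `O=C(CCc1cccc2c1B(O)OC2)Nc1ccc(I)cc1` gives 49000 nM.

Within the data shown here, compound 3 holds the only true number in the set. The rest of the series sits at the limit of > 100000 nM in this assay, at which 2 of the 3 values shown sit. The next compound is compound 4 `Cc1ccc(NC(=O)CCc2cccc3c2B(O)OC3)cc1`, which carries methyl in place of iodo on an aromatic carbon, para to a large group (methyl in place of iodo on an aromatic carbon). The same difference reads 4-iodophenyl to 4-methylphenyl.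

Among the measured compounds shown here, two measured steps bear on this change, and both replace an alkyl group on the amide nitrogen with 4-iodophenyl. The first is an at least 2.0-fold lower number from compound 1 to compound 3 (0.30 log units; that floor lies within the scatter). The second is an at least 2.0-fold lower number from compound 2 to compound 3 (0.30 log units; that floor lies within the scatter). For the measured compounds named here, neither step separates the iodo from the phenyl ring that carries it, and no measured compound makes that separation. Compound 4 keeps the phenyl ring, so it is expected to stay close to compound 3 at 49000 nM, with a slight drift towards a higher number. The step expected in this assay is a 1.3-fold higher number from compound 3 to compound 4 (0.12 log units; within the scatter) and should not exceed the scatter. For compound 4 the estimated value is 65000 nM with an expected range from 30000 nM to 100000 nM.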

Compound 4, half-maximal inhibitory concentration: > 100000 nM
Compound 4: a limit, no number; the forecaster's own chance of this, stated with the estimate: 30%; at least 1.5-fold (0.18 log units) between middle value and limit.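

In this assay, methyl in place of iodo on an aromatic carbon, para to a large group, gives an at least 2.0-fold higher number from compound 3 to compound 4 (0.30 log units; that floor lies within the scatter). The earlier compounds shown here could not separate the iodo from the phenyl ring that carries it; compound 4 keeps that ring and gives only a limit, so the phenyl ring alone does not yield a true number, although the readable floor of the step does not exceed the scatter. The steps from compound 1 and from compound 2 to compound 4 cannot be read, since both ends of each are limits, and compound 3 remains the only compound with a true number, the others sharing one ceiling: the limit of > 100000 nM in this assay, at which 3 of the 4 values shown sit.

The compounds shown leave open whether a bromo or chloro group at the same place would give a true number as iodo does in compound 3, and whether the plain phenyl amide would sit at the limit with compound 4. From the compounds shown here alone, how far compound 4 lies past its limit also stays open, so the full size of the change from iodo to methyl is unknown.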